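The compounds below may be only part of what the source reports. "The series", "measured", "known", "first", "only" and "open" are said of these compounds alone.

Among the compounds with values here, in a physicochemical assay for lipophilicity, read by HPLC, at pH 7.5 (on this read-out higher numbers stand for higher lipophilicity and lower numbers for lower lipophilicity), compound 1 (`CC[C@@H](Nc1c(C#N)c(-c2ccc(-c3ccccc3F)cc2)nc2cnccc12)C(N)=O`) gives 2.7 as its reading, the lower of the two numbers available so far. The other measured compound, compound 2 (`CCOc1ccccc1-c1ccc(-c2nc3cncc(Cl)c3c(N[C@H](CC)C(N)=O)c2C#N)cc1`), gives 3.7 on the same scale, a gap beyond the usual scatter of repeated measurements. Compound 3 (`CC[C@@H](Nc1c(C#N)c(-c2ccc(-c3cccc(C)c3F)cc2)nc2cnccc12)C(N)=O`) has not yet been measured. It departs from compound 1 at a single place (methyl in place of hydrogen on an aromatic carbon): methyl in place of hydrogen on an aromatic carbon, ortho to a fluoro group and meta to a large group, so that 2-fluorophenyl becomes 2-fluoro-3-methylphenyl. Within the data shown here, no pair of measured compounds differs in just one place, and the data hold no direct measure of such a change. A small upward step in this assay is expected for this one added methyl, about the size of the scatter or slightly more. The estimated step is a number 0.40 log units higher from compound 1 to compound 3 (beyond the scatter) in size, a modest rise. For compound 3 the estimated value is 3.1 with an expected range from 2.8 to 3.5 on this scale.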

Compound 3, distribution coefficient: 3
Compound 3: middle estimate off by 0.10 log units, on the high side; the range from low to high includes it.
By their numbers in this assay, from the lowest: compounds 1 and 3 (each within the scatter of the next); then compound 2.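

Within the data shown here, replacing a hydrogen on an aromatic carbon with a methyl, which turns 2-fluorophenyl into 2-fluoro-3-methylphenyl, gives the first direct one-place comparison: in this assay the step is a number 0.30 log units higher from compound 1 to compound 3 (within the scatter). At this carbon, ortho to a fluoro group and meta to a large group, one added carbon therefore leaves compounds 1 and 3 within the usual spread of repeated measurements, so this single pair does not separate them on this read-out. The data offer no independent measurement that could explain the size of this step.

The compounds shown leave open whether a different group on this same carbon, such as an amine, a carboxylic acid or a longer chain like propyl, would give a step that clearly exceeds the scatter. Among these compounds, they also leave open whether the same methyl would give a similar step on another carbon of this ring or on a compound with a different core, since this one pair is the only direct comparison available.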